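The source may hold more compounds than are shown below. What is called first, only, known or untested is meant among the compounds shown, and "the series" means these compounds.

In a functional assay on HCT-116 cells (Homo sapiens) for cytotoxicity, read by MTT assay, with a stated time of 72 h (a lower number here means a stronger inhibitor, a higher number a weaker inhibitor), three compounds on a shared core differ only in the group on a nitrogen on an aromatic ring. Compound 1 (`C[C@@H](Nc1c(C(=O)NCc2ccc(F)cc2)nc(Br)c2cccnc12)c1ccccc1`) gives > 20000 nM, which is a limit and not a number. Compound 3 (`O=C(NCc1ccc(F)cc1)c1nc(Br)c2cccnc2c1NCCO`) gives > 20000 nM, which is also only a limit. Going by the values given here, compound 2 (`NCCCNc1c(C(=O)NCc2ccc(F)cc2)nc(Br)c2cccnc12`) gives 18000 nM, the one true number so far. The series therefore stands at the limit of > 20000 nM in this assay, at which 2 of the 3 values shown sit.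

Compound 4 (`O=C(NCc1ccc(F)cc1)c1nc(Br)c2cccnc2c1N1CCNCC1`) carries piperazin-1-yl in place of the (2-hydroxyethyl)amino of compound 3, on an aromatic carbon para to a bromo group: piperazin-1-yl in place of (2-hydroxyethyl)amino on an aromatic carbon.

The closest guides are the earlier swaps at this same place. They show an at least 1.1-fold lower number from compound 1 to compound 2 (0.04 log units; that floor lies within the scatter), an at least 1.1-fold higher number from compound 2 to compound 3 (0.04 log units; that floor lies within the scatter) and a step that the two limits leave unreadable from compound 1 to compound 3, so none shows a step beyond the scatter. Compound 3 sits at a limit, so a readable move could only appear toward a lower number, and little or none beyond the scatter is expected in this assay. The expected change is an at least 1.3-fold lower number from compound 3 to compound 4 (0.12 log units; that floor lies within the scatter). For compound 4 the estimated value is 15000 nM, with an expected range from 5000 nM to 30000 nM.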

Compound 4, half-maximal inhibitory concentration: > 10000 nM
Compound 4 ended at the assay's limit; the forecaster's own chance of this, stated with the estimate: 45%; the middle value lies beyond the limit too.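

In this assay compound 4 gives > 10000 nM, which is a limit and not a number. Its steps from compound 1, compound 2 and compound 3 cannot be read. The compounds shown leave open how piperazin-1-yl truly compares with the other groups at this place.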